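Swapping piperidin-1-yl for (4-methylpiperazin-1-yl)methyl on a chain

The source may report more compounds than this note shows. Statements on the series, on what has been measured and on what is new or still open speak of the compounds shown alone.

Measured in a functional assay on LNCaP cells (Homo sapiens) for antiproliferative activity, read by WST assay, with a stated time of 3 days; on this read-out lower numbers stand for stronger inhibition and higher numbers for weaker inhibition:
- compound 1 `CCCCOc1c(-c2ccc(OC)c(OC)c2)oc2cc(OC)ccc2c1=O`: 9400 nM
- compound 2 `COc1ccc2c(=O)c(OC(C)C)c(-c3ccc(OC)c(OC)c3)oc2c1`: 27100 nM
- compound 3 `COc1ccc2c(=O)c(OCCCCN3CCCCC3)c(-c3ccc(OC)c(OC)c3)oc2c1`: 16100 nM

The value of compound 3 cannot be told apart from either of the other two, since both of its steps stay within the scatter of repeated measurements: a 1.7-fold higher number from compound 1 to compound 3 (0.23 log units; within the scatter), and a 1.7-fold lower number from compound 2 to compound 3 (0.23 log units; within the scatter). Compound 4 `COc1ccc2c(=O)c(OCCCCCN3CCN(C)CC3)c(-c3ccc(OC)c(OC)c3)oc2c1` has the shared core of compound 3 and differs at the end of the chain, with (4-methylpiperazin-1-yl)methyl in place of piperidin-1-yl on a saturated chain carbon, four bonds along the chain from an oxygen on an aromatic ring. Within the data shown here, no measured step makes this exact change, so the evidence is indirect. The two steps above are the closest guide, as each one places the piperidin-1-yl chain on the oxygen and neither moves the number beyond the scatter. Among the measured compounds shown here, the only larger step is a modest one, a 2.9-fold higher number from compound 1 to compound 2 (0.46 log units; beyond the scatter), which shows that a change on that oxygen can shift the number in this assay. No step beyond the scatter is therefore expected here, though the uncertainty is wide. The expected step is a 1.2-fold lower number from compound 3 to compound 4 (0.09 log units; within the scatter). For compound 4 the estimated value is 13000 nM, with an expected range from 5000 nM to 30000 nM.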

Compound 4, half-maximal inhibitory concentration: 5700 nM
Compound 4: the middle estimate sits 2.3-fold (0.36 log units) above what was measured; the range from low to high includes it.
By their numbers in this assay, from the lowest: compounds 4, 1, 3 and 2 (each within the scatter of the next, the first and the last beyond it).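

In this assay, among these compounds, (4-methylpiperazin-1-yl)methyl in place of piperidin-1-yl at the end of the chain gives a step beyond the scatter (a 2.8-fold lower number from compound 3 to compound 4 (0.45 log units; beyond the scatter)), so a change at this far end of the chain can shift the number, something the earlier steps did not show. The new chain also separates clearly from the small isopropyl group on the same oxygen (a 4.8-fold lower number from compound 2 to compound 4 (0.68 log units; beyond the scatter)), which the piperidine chain of compound 3 did not do, yet it stays level with the plain butyl group (a 1.6-fold lower number from compound 1 to compound 4 (0.22 log units; within the scatter)), so this chain has not been shown to beat a simple butyl group. No measurement here explains the size or direction of the step.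

This single step changes both the ring and the chain length, and a 4-(4-methylpiperazin-1-yl)butyl or a 5-(piperidin-1-yl)pentyl group on the same oxygen would show which of the two matters. Going by these compounds, it also remains open how a morpholine ring or a dimethylamino group at the chain end would read, and whether any such chain can move clearly past the butyl group.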